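Series notes: pyrazolyl for oxazolyl on the dichloro core

The source may hold more compounds than are shown below. What is called first, only, known or untested is meant among the compounds shown, and "the series" means these compounds.

Compound 1, `Cc1cc(C)c(CN2CCc3ccc(-c4c(C)noc4C)c(Cl)c3C2=O)c(=O)[nH]1`, in a physicochemical assay for lipophilicity, at pH 7.4 (a lower number here means a more polar compound, a higher number a more lipophilic compound), gives 2.6.
Compound 2, `Cc1cc(C)c(CN2CCc3c(C)cc(O[C@@H]4CCOC4)c(Cl)c3C2=O)c(=O)[nH]1`, in this assay gives 2.1.
Compound 3, `Cc1cc(C)c(CN2CCc3c(Cl)cc(-c4c(C)noc4C)c(Cl)c3C2=O)c(=O)[nH]1`, in this assay gives 3.1.

Compound 3 stands highest of the three numbers in this assay. Among the compounds with values here, the nearest is compound 1; the only single-point step in the set, a number 0.50 log units higher from compound 1 to compound 3 (beyond the scatter), is beyond the scatter and comes from chloro in place of hydrogen on an aromatic carbon. Within the data shown here, compound 2 is the furthest from compound 3 and sits lowest of the three in this assay; no single-point step connects them.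

Compound 4, `Cc1cc(C)c(CN2CCc3c(Cl)cc(-c4cn[nH]c4C)c(Cl)c3C2=O)c(=O)[nH]1`, follows from compound 3 by one change: 5-methyl-1H-pyrazol-4-yl in place of 3,5-dimethyl-1,2-oxazol-4-yl on an aromatic carbon. Among the measured compounds shown here, no measured step covers an exchange of this kind; the step of a number 0.50 log units higher from compound 1 to compound 3 (beyond the scatter) concerns a different change and does not bear on it directly. The expectation therefore rests on the change itself, in which a group with no hydrogen-bond donor leaves and one with one hydrogen-bond donor enters. From compound 3 a step of a number 0.80 log units lower from compound 3 to compound 4 (beyond the scatter) is expected in this assay, beyond the scatter and downward. Compound 4 is estimated at 2.3, with a range from 1.8 to 2.8.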

Compound 4, distribution coefficient: 3.1
Beside the measured number, compound 4's estimate is 0.80 log units below it; the whole stated range lies below it.
By their numbers in this assay, from the lowest: compound 2; then compound 1; then compounds 3 and 4 (each within the scatter of the next).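

On the aromatic carbon ortho to a chloro group, the exchange of 3,5-dimethyl-1,2-oxazol-4-yl for 5-methyl-1H-pyrazol-4-yl gives in this assay no change at the digits printed from compound 3 to compound 4 (within the scatter), so in this pair a group with 1 hydrogen-bond donor reads alike with a group with 0 hydrogen-bond donors. Within the data shown here, the only earlier step, a number 0.50 log units higher from compound 1 to compound 3 (beyond the scatter), came from chloro in place of hydrogen and did not touch this position. No measurement at hand bears on why the two groups read alike.

The compounds shown leave open whether the exchange reads the same on the core of compound 1. They also leave open whether a group of another kind on this carbon, such as a carboxylic acid or a primary amine on a longer chain, would move the number.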